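Fluorinated groups on the aniline ring of a shared core

A few compounds are considered here, and "the series" means these few. Any claim that something is new, unique, unknown or untested is made for them only; others in the source may bear on it.

Measured so far:
- compound 1, `Oc1nc2nonc2nc1Nc1ccccc1`: 66700 nM
- compound 2, `Oc1nc2nonc2nc1Nc1cccc(C(F)(F)F)c1`: 13300 nM

Both compounds were tested in an assay on mitochondria from L6 cells (Rattus norvegicus) for activation, with a stated time of 90 min; on this read-out lower numbers stand for an effect already at smaller amounts and higher numbers for an effect only at larger amounts of compound. Going by the values given here, compound 1 is the one with the highest number of the two; its nearest neighbour is compound 2, and the change from compound 1 to compound 2 is a 5.0-fold lower number from compound 1 to compound 2 (0.70 log units; beyond the scatter), which is trifluoromethyl in place of hydrogen on an aromatic carbon of the ring attached to the shared core.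

Compound 3, `Oc1nc2nonc2nc1Nc1ccc(OC(F)(F)C(F)F)cc1`, has not yet been measured. It differs from compound 1 by 1,1,2,2-tetrafluoroethoxy in place of hydrogen on an aromatic carbon. Among the compounds with values here, the only measured step that bears on this is the one from compound 1 to compound 2, where a fluorine-rich group entering the same ring gave a modest improvement. On that basis, a fluorine-rich group entering this ring in compound 3 is expected to give a step of similar size in the same direction, a 3.7-fold lower number from compound 1 to compound 3 (0.57 log units; beyond the scatter), though the different group and different place add uncertainty. Compound 3 is therefore estimated at 18000 nM, with a range of 6000 nM to 50000 nM.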

Compound 3, half-maximal effective concentration: 7000 nM
Beside the measured number, compound 3's estimate is 2.6-fold (0.41 log units) above it, and the stated range covers the measured number.
By their numbers in this assay, from the lowest: compounds 3 and 2 (each within the scatter of the next); then compound 1.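

In this assay, 1,1,2,2-tetrafluoroethoxy on an aromatic carbon para to a large group gives a 9.5-fold lower number from compound 1 to compound 3 (0.98 log units; beyond the scatter). This shows that the place can hold a chain of this size, far larger than the hydrogen it replaces, and the number still falls rather than rises. Going by these compounds alone, it also means that a lower number on the aniline ring is no longer tied to trifluoromethyl alone, as it was when compound 2 was the only substituted example, although two compounds with different groups in different places do not make a general rule. Nothing measured here explains why the number falls, so the cause of the step remains unknown.

The compounds shown leave open how much of the step comes from the fluorine atoms and how much from the chain itself, a question that a plain ethoxy group in the same place could help to separate. They also leave open how this place would respond to a group of a different kind, such as an amine or a carboxylic acid.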